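Amide nitrogen variation in the dimethoxy series

This account rests on a few compounds, and the source may have more. Where it says the series, first, only, none or still open, it means among the compounds named here.

Measured so far:
compound 1 `COc1cc2c(cc1OC)C(CC(N)=O)CC2`, 31%
compound 2 `CCCNC(=O)CC1CCc2cc(OC)c(OC)cc21`, 28%
compound 3 `COc1cc2c(cc1OC)C(CC(=O)N1CCCCC1)CC2`, 22%

In a functional assay on the whole organism (strain Wistar) for inhibition, with Rattus norvegicus as the target, read by paw edema, with stated times of 60 min and 2 h, at a dose of 100 mg/kg by the oral route (on this read-out higher numbers stand for more inhibition at the one dose given (going by the name of the read-out) and lower numbers for less inhibition), compound 3 gives 22%, and it sits within the scatter of both compound 1 and compound 2: a number 9 percentage points lower from compound 1 to compound 3 (within the scatter), a number 6 percentage points lower from compound 2 to compound 3 (within the scatter). Compound 4 `COc1cc2c(cc1OC)C(CC(=O)NCCO)CC2` carries the change ((2-hydroxyethyl)amino in place of piperidin-1-yl on a carbonyl carbon). Going by the values given here, the steps that bear on it are those altering the substituent on the amide-type nitrogen of the same core, and none of them moved the read-out beyond the scatter; the step of a number 3 percentage points lower from compound 1 to compound 2 (within the scatter) fits the same picture. A step in this assay of a number 5 percentage points higher from compound 3 to compound 4 (within the scatter) is therefore expected, not beyond the scatter. Compound 4 is estimated at 27%, with a range from 15% to 40%.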

Compound 4, a percentage reported as inhibition, in the whole organism at one dose (the size of the read-out at that dose, not a potency): 0%
Beside the measured number, compound 4's estimate is 27 percentage points above it; the measured number lies below the stated range.
By their numbers in this assay, from the lowest: compound 4; then compounds 3, 2 and 1 (each within the scatter of the next).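

In this assay, going by these compounds alone, the substituent on the amide-type nitrogen is no longer silent: (2-hydroxyethyl)amino in place of piperidin-1-yl on the carbonyl carbon gives a number 22 percentage points lower from compound 3 to compound 4 (beyond the scatter), the first step beyond the scatter. Hydroxy in place of methyl on the saturated chain carbon gives a number 28 percentage points lower from compound 2 to compound 4 (beyond the scatter), and 2-hydroxyethyl in place of hydrogen on the amide-type nitrogen gives a number 31 percentage points lower from compound 1 to compound 4 (beyond the scatter). No measurement here accounts for this drop.

Going by these compounds, whether the drop is tied to the hydroxy group or to the chain remains open. A 2-methoxyethyl, 2-aminoethyl or 3-hydroxypropyl group on the same nitrogen would test this.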